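Aryl for methyl on the tetrazole of compound 2

This account rests on a few compounds, and the source may have more. Where it says the series, first, only, none or still open, it means among the compounds named here.

Compound 1, `CCCCCCCCc1ccc(OCC(=O)Cn2nnc(C(=O)O)n2)cc1`, gives 41 nM in an assay on microsomes from brain for inhibition of Fatty-acid amide hydrolase 1 (Rattus norvegicus), read by fluorescence and HPLC, with a stated time of 60 min; on this read-out lower numbers stand for stronger inhibition and higher numbers for weaker inhibition.
Compound 2, `CCCCCCCCc1ccc(OCC(=O)Cn2nnnc2C)cc1`, gives 41 nM in this assay.

Compound 2 stands level with compound 1 at the digits shown: the step of no change at the digits printed from compound 1 to compound 2 (within the scatter) lies within the scatter, so the two compounds cannot be placed in order on this read-out.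

Compound 3, `CCCCCCCCc1ccc(OCC(=O)Cn2nnnc2-c2cccc(Cl)c2)cc1`, has not yet been measured in this assay. It differs from compound 2 by 3-chlorophenyl in place of methyl on an aromatic carbon. For the measured compounds named here, no measured step touches this kind of change: the only step on record, from compound 1 to compound 2, swaps one tetrazole for another and leaves the potency unchanged, and it says nothing about enlarging the group on the aromatic carbon. The expectation for compound 3 therefore rests on the shared core alone, and the step of a 1.0-fold lower number from compound 2 to compound 3 (0.01 log units; within the scatter) is estimated as none beyond the scatter, with a wide range on either side. Compound 3 is expected to give about 40 nM in this assay, between 8 nM and 250 nM.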

Compound 3, half-maximal inhibitory concentration: 360 nM
For compound 3 the middle estimate is 9.0-fold (0.95 log units) below the measured one, outside the stated range (above it).
By their numbers in this assay, from the lowest: compounds 1 and 2 (each within the scatter of the next); then compound 3.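

In this assay the carbon of the five-membered aromatic ring with 4 nitrogen turns out not to be indifferent to what it carries: 3-chlorophenyl in place of methyl gives an 8.8-fold higher number from compound 2 to compound 3 (0.94 log units; beyond the scatter). The earlier pair had shown only that one substituted tetrazole could stand in for another with no change beyond the scatter, so this is the first step in the series that separates two compounds on this read-out, and it points to this carbon as a place where the group matters. Nothing among the data given accounts for the higher number.

The compounds shown leave open whether that higher number goes with the aromatic ring or with the chlorine, a question that a plain phenyl group at the same carbon would separate. They also leave open how the number moves across the range between methyl and 3-chlorophenyl, for instance with an ethyl group, or with a chlorine on a different ring carbon of the phenyl group.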